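The compounds below may be only part of what the source reports. "The series", "measured", "known", "first", "only" and "open" are said of these compounds alone.

Working notes on the series. In a functional assay on HepG2 cells (Homo sapiens) for antiproliferative activity, read by MTT assay, with a stated time of 48 h (on this read-out higher numbers stand for weaker inhibition and lower numbers for stronger inhibition), compound 1 (`COc1ccc(/C=C/c2cc(OC)cc(OC)c2/C=C/C(=O)c2ccc(C)cc2)cc1`) gives 4.8 ug/mL and compound 2 (`COc1ccc(/C=C/c2cc(OC)cc(OC)c2/C=C/C(=O)c2ccccc2)cc1`) gives 6.8 ug/mL. Among the compounds with values here, compound 2 therefore stands level with compound 1 within the scatter, and these are the only two numbers so far. The next structure is compound 3 (`COc1ccc(/C=C/c2cc(OC)cc(OC)c2/C=C/C(=O)c2ccc(OC)cc2)cc1`), which has methoxy in place of hydrogen on an aromatic carbon of compound 2, para to a large group: methoxy in place of hydrogen on an aromatic carbon. Within the data shown here, one measured step bears on this carbon, where hydrogen replaces methyl: a 1.4-fold higher number from compound 1 to compound 2 (0.15 log units; within the scatter). Among the measured compounds shown here, that step is small and stays inside the scatter, but it is the only evidence available. For the measured compounds named here, no compound with methoxy at this place has been measured in this assay, so the direction of any shift remains open. No step beyond the scatter is expected, and the estimate corresponds to a 1.2-fold lower number from compound 2 to compound 3 (0.09 log units; within the scatter). For compound 3, the expected value is 5.5 ug/mL, with an estimated range of 2.5 ug/mL to 12 ug/mL.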

Compound 3, half-maximal inhibitory concentration: 4.9 ug/mL
Beside the measured number, compound 3's estimate is 1.1-fold (0.05 log units) above it; the range from low to high includes it.
By their numbers in this assay, from the lowest: compounds 1, 3 and 2 (each within the scatter of the next).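

Compound 3 carries a hydrogen-bond acceptor on this carbon, para to a large group, where compound 1 and compound 2 carry none, yet in this assay the step reads a 1.4-fold lower number from compound 2 to compound 3 (0.14 log units; within the scatter) and does not leave the scatter. The exchange of the two non-hydrogen groups reads a 1.0-fold higher number from compound 1 to compound 3 (0.01 log units; within the scatter) and is also within the scatter, so hydrogen, methyl and methoxy at this carbon, in compound 2, compound 1 and compound 3, cannot be told apart on this read-out, and the earlier single step between hydrogen and methyl now extends to a group with a different atom count and an oxygen. No measurement on hand gives a reason for this level picture.

On these data alone, whether an amine or a carboxylic acid on this carbon would also stay within the scatter of compound 2 remains open, and a single series of three neutral groups cannot settle it. As far as these compounds go, a longer chain such as butoxy in place of methoxy is equally open, and since all three compounds share the rest of the core, nothing here tells how changes elsewhere in it would read.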